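Replacing the 4-Fluorophenyl Group of Compound 2

The compounds below may be only part of what the source reports. "The series", "measured", "known", "first", "only" and "open" are said of these compounds alone.

Compound 1 `COc1ccc2cc([C@H](C)c3nnc(SCc4c(C)cc(C)cc4C)n3-c3cccc(Cl)c3)ccc2c1`: <= 400000 nM (a limit)
Compound 2 `COc1ccc2cc([C@H](C)c3nnc(SCc4ccc(F)cc4)n3-c3ccc(F)cc3)ccc2c1`: 104000 nM

Going by the values given here, in a functional assay on LNCaP cells (Homo sapiens) for cytotoxicity, read by MTT assay (a higher number here means a weaker inhibitor, a lower number a stronger inhibitor), compound 2 gives 104000 nM, the only true number so far. The entry for compound 1, <= 400000 nM, is a limit. Compound 3 `COc1ccc2cc([C@H](C)c3nnc(SCc4c(C)cc(C)cc4C)n3-c3ccc(F)cc3)ccc2c1` differs from compound 2 in one place: 2,4,6-trimethylphenyl in place of 4-fluorophenyl on a saturated chain carbon bound to a sulfur. Here, 2,4,6-trimethylphenyl stands in place of 4-fluorophenyl on a saturated chain carbon bound to a sulfur. Among the compounds with values here, no measured pair shows this change, so the expectation rests on compound 2 at 104000 nM, with no shift in either direction beyond the scatter in this assay. The expected step is a 1.0-fold lower number from compound 2 to compound 3 (0.02 log units; within the scatter). For compound 3 the estimated value is 100000 nM, with an expected range of 35000 nM to 300000 nM.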

Compound 3, half-maximal inhibitory concentration: 2210 nM
The estimate for compound 3 lay 45-fold (1.66 log units) above the measured number; the measured number lies below the stated range.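

In this assay, going by these compounds alone, this is the first step that can be read, and it shows that the group on the saturated chain carbon bound to a sulfur strongly affects the result: 2,4,6-trimethylphenyl in place of 4-fluorophenyl gives a 47-fold lower number from compound 2 to compound 3 (1.67 log units; beyond the scatter). Compound 1 carries a limit, not a number, so its step to compound 3 cannot be read: the limit of <= 400000 nM in this assay, at which 1 of the 3 values shown sits.

Whether the methyl groups or the missing fluorine account for the step stays open. So does how an unsubstituted phenyl, a cyclohexyl or an amine-bearing ring would behave at this place.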